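The source may report more compounds than this note shows. Statements on the series, on what has been measured and on what is new or still open speak of the compounds shown alone.

Compound 1, `COc1cc(-c2nnc(SCC(=O)c3ccccc3)n2N)cc(OC)c1OC`: > 100000 nM in a functional assay on PC-3 cells (Homo sapiens) for antiproliferative activity, read by MTT assay, with a stated time of 48 h (on this read-out lower numbers stand for stronger inhibition and higher numbers for weaker inhibition), a limit of the assay.
Compound 2, `COc1cc(-c2nnc(SCC(=O)c3ccc(C)cc3)n2N)cc(OC)c1OC`: 31300 nM in this assay.
Compound 3, `COc1cccc(NC(=O)CSc2nnc(-c3cc(OC)c(OC)c(OC)c3)n2N)c1`: > 100000 nM in this assay, a limit of the assay.

Compound 3 therefore has no number of its own in this assay, only a limit, and it shares that position with compound 1, as the limit of > 100000 nM in this assay, at which 2 of the 3 values shown sit, records. The step from the measured amide compound 2 is an at least 3.1-fold higher number from compound 2 to compound 3 (0.50 log units; beyond the scatter), while a step that the two limits leave unreadable from compound 1 to compound 3 cannot be read because both ends sit at a limit. Compound 4, `COc1cc(-c2nnc(SCC(=O)NCc3ccc(Cl)cc3)n2N)cc(OC)c1OC`, keeps the amide of compound 3 and changes only the group on its nitrogen: 4-chlorobenzyl in place of 3-methoxyphenyl on an amide-type nitrogen. Within the data shown here, no measured step touches this position with a benzyl group, so the expectation rests on compound 3 standing at the limit and on an at least 3.1-fold higher number from compound 2 to compound 3 (0.50 log units; beyond the scatter) showing the amide series weaker than the ketone compound 2. The step is expected to be an at least 1.2-fold lower number from compound 3 to compound 4 (0.09 log units; that floor lies within the scatter), and compound 4 is estimated at 80000 nM, between 20000 nM and 300000 nM.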

Compound 4, half-maximal inhibitory concentration: > 100000 nM
Compound 4: no number, only a limit; the forecaster's own chance of this, stated with the estimate: 55%; middle value at least 1.2-fold (0.09 log units) away from the limit.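

Compound 4 also gives only a limit of the assay, so a benzyl group carrying chlorine on the amide-type nitrogen, in place of 3-methoxyphenyl, still leaves this assay without a number for any amide shown: the limit of > 100000 nM in this assay, at which 3 of the 4 values shown sit. The steps to compound 4 from compound 3 and from compound 1 cannot be read, since both ends of each are limits. Among these compounds, the one readable step is an at least 3.1-fold higher number from compound 2 to compound 4 (0.50 log units; beyond the scatter), which puts a second amide short of the ketone compound 2, although the unsubstituted ketone compound 1 also stands at the limit, so the amide alone does not mark the divide.

As far as these compounds go, whether the group on the amide nitrogen matters at all stays open. Also open, from the compounds shown here alone, is how a morpholine amide, or a carboxylic acid in place of the amide, would read.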